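The source may report more compounds than this note shows. Statements on the series, on what has been measured and on what is new or still open speak of the compounds shown alone.

Working notes on the carbamate series. Compound 1 `C#CCN1CCC(OC(=O)Nc2ccc(C(C)C)cc2)CC1` in an assay on BTI-TN-5B1-4 cells for inhibition of Amine oxidase [flavin-containing] A (Homo sapiens), read by fluorescence and Amplex Red, using microsomes, with a stated time of 15 min (a lower number here means a stronger inhibitor, a higher number a weaker inhibitor), gives only the limit > 100000 nM. Compound 2 `C#CCN1CCCC(OC(=O)Nc2ccc(C(C)C)cc2)C1` has the same atoms as compound 1 joined differently; how the two cores differ is not broken down here. In this assay compound 2 likewise gives only the limit > 100000 nM. Compound 3 `CC(C)c1ccc(NC(=O)OC2CCN(Cc3ccccc3)CC2)cc1` carries phenyl in place of ethynyl on a saturated chain carbon bound to an amine nitrogen in a ring relative to compound 1, and in this assay compound 3 returns only the limit > 100000 nM. The step that the two limits leave unreadable from compound 1 to compound 3 cannot be sized because of the limit of > 100000 nM in this assay, at which 3 of the 3 values shown sit.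

Compound 4 `CC(C)c1ccc(NC(=O)OC2CCCN(Cc3ccccc3)C2)cc1` carries the same change on the core of compound 2: phenyl in place of ethynyl on a saturated chain carbon bound to an amine nitrogen in a ring. The expectation for compound 4 rests on compound 2 giving only the limit > 100000 nM, so the step from compound 2 to compound 4 is expected as a step that the limit leaves unreadable from compound 2 to compound 4, most likely a further limit. Compound 4 is expected at 150000 nM, between 30000 nM and 1000000 nM.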

Compound 4, half-maximal inhibitory concentration: > 100000 nM
Compound 4: a limit, no number; the forecaster's own chance of this, stated with the estimate: 85%; the middle value is on the limit's open side.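

No step can be read between compound 2 and compound 4, because both give only a limit: the limit of > 100000 nM in this assay, at which 4 of the 4 values shown sit.

The compounds shown leave open whether propargyl or benzyl, on either core, makes any difference in this assay.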